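This account rests on a few compounds, and the source may have more. Where it says the series, first, only, none or still open, it means among the compounds named here.

For the measured compounds named here, in a functional assay on HCT-15 cells (Homo sapiens) for cytotoxicity, in the presence of a further agent that is not named here (a higher number here means a weaker inhibitor, a lower number a stronger inhibitor), compound 1 `Clc1ccc(-c2cc(-c3ccc(Cl)o3)cc(-c3ccsc3)n2)cc1` gives 5190 nM, the lowest number of the series so far. Compound 3 `Clc1ccc(-c2cc(-c3ccc(Cl)o3)cc(-c3cccs3)n2)cc1` gives 14200 nM. Thiophen-2-yl in place of thiophen-3-yl thus makes a 2.7-fold higher number from compound 1 to compound 3 (0.44 log units; beyond the scatter). Compound 2 `Clc1ccc(-c2cc(-c3ccoc3)cc(-c3ccsc3)n2)cc1` reads > 100000 nM, which is a limit of the assay. Furan-3-yl in place of 5-chlorofuran-2-yl makes an at least 19-fold higher number from compound 1 to compound 2 (1.28 log units; beyond the scatter), the large step of the series.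

Compound 4 `Clc1cccc(-c2cc(-c3ccc(Cl)o3)cc(-c3ccsc3)n2)c1` is not yet measured. Its change from compound 1 is 3-chlorophenyl in place of 4-chlorophenyl on an aromatic carbon, with 3-chlorophenyl in place of 4-chlorophenyl. Neither measured step touches the chlorophenyl group. The nearer guide is compound 3, where the same atoms joined differently gave a 2.7-fold higher number from compound 1 to compound 3 (0.44 log units; beyond the scatter), so a modest step is expected rather than a large one. In this assay the expected direction is towards a higher number, as compound 1 stands lowest at 5190 nM, though this rests on little data.

For compound 4 the estimated value is 9000 nM, with an expected range of 3000 nM to 30000 nM. The estimate amounts to a 1.7-fold higher number from compound 1 to compound 4 (0.24 log units; within the scatter).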

Compound 4, half-maximal inhibitory concentration: 13700 nM
Estimate against measurement, compound 4: 1.5-fold (0.18 log units) below, and the stated range covers the measured number.
By their numbers in this assay, from the lowest: compound 1; then compounds 4 and 3 (each within the scatter of the next). At a limit, above all of these: compound 2.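

Moving the chlorine on the phenyl group next to the ring nitrogen is the first change at this position, and it is not neutral in this assay: 3-chlorophenyl in place of 4-chlorophenyl gives a 2.6-fold higher number from compound 1 to compound 4 (0.42 log units; beyond the scatter). With the atom count unchanged, the placement of the chlorine alone shifts the number, and 4-chlorophenyl gives the lower number of this pair. The step is modest, and nothing shown accounts for its cause.

As far as these compounds go, the change is read in one setting only, with 5-chlorofuran-2-yl and thiophen-3-yl on the shared core, so its size alongside other groups remains open. Also open, from the compounds shown here alone, is how the number would respond on this phenyl to an amine or a carboxylic acid in place of the chlorine.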